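This account rests on a few compounds, and the source may have more. Where it says the series, first, only, none or still open, it means among the compounds named here.

Compound 2 `CC(=O)OCCOCN1c2ccccc2C(=O)NS1(=O)=O` stands at the ceiling of a functional assay on HEL cells (Homo sapiens) for cytotoxicity; a lower number here means that less compound is tolerated, a higher number that more compound is tolerated: in this assay compound 2 gives > 50 ug/mL, which is a limit rather than a number. Compound 1 `O=C1c2ccccc2N(COCc2ccccc2)S(=O)(=O)N1Cc1ccccc1` is likewise at a limit, since in this assay compound 1 gives > 50 ug/mL. Both values sit on (the limit of > 50 ug/mL in this assay, at which 2 of the 2 values shown sit). Compound 3 `CCCOCN1c2ccccc2C(=O)NS1(=O)=O` differs from compound 2 by methyl in place of acetoxy on a saturated chain carbon, two bonds along the chain from an oxygen on a saturated carbon. Within the data shown here, no measured step between compounds exists, so the two limits alone guide the expectation. The expected step is a step that the limit leaves unreadable from compound 2 to compound 3, none beyond the scatter. Compound 3 is therefore estimated at 60 ug/mL, ranging from 30 ug/mL to 150 ug/mL.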

Compound 3, minimum cytotoxic concentration: > 50 ug/mL
Compound 3 gave a limit, no number; the forecaster's own chance of this, stated with the estimate: 85%; the middle value lies beyond the limit too.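

No step can be read from compound 2 to compound 3, because both values are limits: the limit of > 50 ug/mL in this assay, at which 3 of the 3 values shown sit. In this assay the compounds shown leave open at what concentration any of them becomes cytotoxic.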